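A few compounds are considered here, and "the series" means these few. Any claim that something is new, unique, unknown or untested is made for them only; others in the source may bear on it.

Compound 1, `O=c1cc(CNCc2ccccc2Cl)oc2ccc(O)c(O)c12`, in an ADME assay on Huh-7 cells (Homo sapiens) for cytotoxicity; a lower number here means that less compound is tolerated, a higher number that more compound is tolerated: > 100000 nM, a limit of the assay.
Compound 2, `O=c1cc(CNCc2ccccc2Br)oc2ccc(O)c(O)c12`, in this assay: > 100000 nM, a limit of the assay.
Compound 3, `O=c1cc(CNCc2cccc(Br)c2)oc2ccc(O)c(O)c12`, in this assay: > 100000 nM, a limit of the assay.

Compound 3 stands where every measured compound stands: its value in this assay is a limit, not a number. The three measured steps, a step that the two limits leave unreadable from compound 1 to compound 2, a step that the two limits leave unreadable from compound 1 to compound 3 and a step that the two limits leave unreadable from compound 2 to compound 3, are therefore all unreadable in size, and the only firm point is the limit of > 100000 nM in this assay, at which 3 of the 3 values shown sit.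

Compound 4, `Cc1cccc(CNCc2cc(=O)c3c(O)c(O)ccc3o2)c1`, differs from compound 3 by methyl in place of bromo on an aromatic carbon. For the measured compounds named here, none of the measured steps gives a readable size that bears on this change, so no step beyond the scatter can be predicted in either direction; the expectation is simply that compound 4 behaves like the measured compounds. The step from compound 3 to compound 4 is expected to be a number no higher from compound 3 to compound 4 (the limit leaves the size open), most likely again only a limit. On that basis compound 4 is estimated at 100000 nM, within a range from 40000 nM to 300000 nM.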

Compound 4, half-maximal cytotoxic concentration: > 100000 nM
Compound 4 was reported as a limit; the forecaster's own chance of this, stated with the estimate: 85%; the middle value sits exactly at the limit.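

Compound 4 is reported only as a limit, like compound 1, compound 2 and compound 3, so its steps to those three compounds cannot be read in size: the limit of > 100000 nM in this assay, at which 4 of the 4 values shown sit. The compounds shown leave open whether the changes among them make any difference in this assay.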